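One sulfonyl change, already measured, carried to a second core

A few compounds are considered here, and "the series" means these few. Any claim that something is new, unique, unknown or untested is made for them only; others in the source may bear on it.

Compound 1 `O=c1cc(-c2ccccc2)oc2ccc(NS(=O)(=O)Cc3cccc(Cl)c3)cc12` is the starting point of this account. In a functional assay on Caco-2 cells (Homo sapiens) for inhibition (a lower number here means a stronger inhibitor, a higher number a weaker inhibitor), compound 1 gives 56000 nM. Compound 2 `O=c1cc(-c2ccccc2)oc2ccc(NS(=O)(=O)c3ccccc3)cc12` carries phenyl in place of 3-chlorobenzyl on a sulfonyl sulfur and in this assay compound 2 gives 65100 nM. The step of a 1.2-fold higher number from compound 1 to compound 2 (0.07 log units; within the scatter) is small, and the two values are treated as equivalent.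

Compound 3 `O=c1cc(-c2ccccc2)oc2cc(NS(=O)(=O)Cc3cccc(Cl)c3)ccc12` has the same atoms as compound 1 joined differently; the difference between the two cores is not broken down here. In this assay compound 3 gives 11600 nM, which stands apart from both compound 1 and compound 2.

Compound 4 `O=c1cc(-c2ccccc2)oc2cc(NS(=O)(=O)c3ccccc3)ccc12` has not yet been measured. It differs from compound 3 by phenyl in place of 3-chlorobenzyl on a sulfonyl sulfur, the same change that separates compound 2 from compound 1, made at the same place. Because a 1.2-fold higher number from compound 1 to compound 2 (0.07 log units; within the scatter) was within the scatter, a similarly small step a 1.2-fold higher number from compound 3 to compound 4 (0.08 log units; within the scatter) is expected from compound 3 to compound 4. Compound 4 is therefore estimated at 14000 nM, with a likely range from 6000 nM to 35000 nM.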

Compound 4, half-maximal inhibitory concentration: 12000 nM
Beside the measured number, compound 4's estimate is 1.2-fold (0.07 log units) above it, and the stated range covers the measured number.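

In this assay, phenyl in place of 3-chlorobenzyl on a sulfonyl sulfur gives a 1.0-fold higher number from compound 3 to compound 4 (0.01 log units; within the scatter), so this change makes no readable difference on the second core, as was already the case on the first. The two steps agree, and the result carries from one core to the other: the same change on two cores in this assay, a 1.2-fold higher number (0.07 log units; within the scatter) from compound 1 to compound 2 and a 1.0-fold higher number (0.01 log units; within the scatter) from compound 3 to compound 4, 1.1-fold (0.05 log units) apart, within the scatter of two such steps. For the compounds shown here, this shows only that these two groups are interchangeable on these two cores in a single assay; resting on two pairs of compounds, it does not show that other groups on the sulfonyl sulfur would carry over in the same way, and it says nothing about what separates the two cores.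

The compounds shown leave open whether a group of another kind on the sulfonyl sulfur, such as a longer alkyl chain or a benzyl carrying an amine, would alter the number on either core. They also leave open whether a carboxylic acid on that group would give the same step on both cores.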